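Chloro in place of hydroxy on compound 3

A few compounds are considered here, and "the series" means these few. Any claim that something is new, unique, unknown or untested is made for them only; others in the source may bear on it.

Of the compounds shown here, three sharing one core have been read in a functional assay on MT4 cells (Homo sapiens) for cytotoxicity, read by MTT assay; on this read-out higher numbers stand for lower toxicity in this test and lower numbers for higher toxicity in this test. Compound 1 `Cc1c(O)nc(S(=O)(=O)Cc2ccc([N+](=O)[O-])cc2)nc1Cc1c(Cl)cccc1Cl` gives > 53000 nM, which is a limit and not a number. Compound 2 `Cc1c(O)nc(SCc2ccc(C#N)cc2)nc1Cc1c(Cl)cccc1Cl` gives > 60000 nM, which is also a limit. Among the compounds with values here, compound 3 `Cc1c(O)nc(SCc2ccc(O)cc2)nc1Cc1c(Cl)cccc1Cl` gives 41000 nM, the only actual number in the set, so its rank against the other two cannot be fixed.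

The next compound is compound 4 `Cc1c(O)nc(SCc2ccc(Cl)cc2)nc1Cc1c(Cl)cccc1Cl`, which carries chloro in place of hydroxy on an aromatic carbon, para to a large group, turning the 4-hydroxybenzyl into a 4-chlorobenzyl (chloro in place of hydroxy on an aromatic carbon).

Within the data shown here, only one measured step bears on this change, and it falls on the same aromatic carbon: an at least 1.4-fold lower number from compound 2 to compound 3 (0.16 log units; that floor lies within the scatter), with hydroxy in place of cyano. That figure is only a floor, and it lies within the scatter. Among the measured compounds shown here, no measured step involves chloro, so the evidence supports no direction. A limit in place of a number would fit the readings of compound 1 and compound 2.

In this assay, the estimated step is a 1.0-fold lower number from compound 3 to compound 4 (0.01 log units; within the scatter), and no change beyond the scatter is expected.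

For compound 4 the expected value is 40000 nM, with an estimated range of 15000 nM to 100000 nM.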

Compound 4, half-maximal cytotoxic concentration: > 59000 nM
Compound 4: only a limit was reported (the forecaster's own chance of this, stated with the estimate: 45%); middle value at least 1.4-fold (0.16 log units) away from the limit.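

In this assay, compound 4 gives > 59000 nM, which is a limit and not a number, so chloro joins cyano as a second group on this aromatic carbon, para to a large group, whose reading is only a limit. Chloro in place of hydroxy gives an at least 1.4-fold higher number from compound 3 to compound 4 (0.15 log units; that floor lies within the scatter), so the change at this position again yields only a floor, as the earlier step with hydroxy in place of cyano did, and neither step establishes a real difference in this test. The step between the chloro and cyano compounds cannot be read, as both ends are limits.

Among the compounds differing only at this position, hydroxy in compound 3 remains the only group with an actual number, and how far compound 2 and compound 4 lie from that number remains open. On these data alone, whether a number within the assay's range also appears with an amine, a carboxylic acid or a methoxy group on the same aromatic carbon is also open, as is whether hydroxy is unusual here at all.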